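From furan-3-yl to 1-benzofuran-2-yl on compound 3

A few compounds are considered here, and "the series" means these few. Any claim that something is new, unique, unknown or untested is made for them only; others in the source may bear on it.

Compound 1 `CSc1ncnc2c1c(-c1ccoc1)cn2[C@@H]1O[C@H](CO)[C@@H](O)[C@H]1O` gives 14200 nM
Compound 2 `CSc1ncnc2c1c(-c1ccsc1)cn2[C@@H]1O[C@H](CO)[C@@H](O)[C@H]1O` gives > 20000 nM (a limit of the assay)
Compound 3 `Nc1nc2c(c(-c3ccoc3)cn2[C@@H]2O[C@H](CO)[C@@H](O)[C@H]2O)c(=O)[nH]1` gives 17900 nM
Compound 4 `Nc1nc2c(c(-c3cc4ccccc4o3)cn2[C@@H]2O[C@H](CO)[C@@H](O)[C@H]2O)c(=O)[nH]1` is not yet measured

In a functional assay on CCRF-CEM cells (Homo sapiens), read by MTT assay, with a stated time of 72 h (on this read-out higher numbers stand for weaker inhibition and lower numbers for stronger inhibition), compound 3 gives 17900 nM and lies within the usual scatter of compound 1 at 14200 nM on the same read-out. Compound 2 reports only a limit, > 20000 nM, and no number.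

Compound 4 carries 1-benzofuran-2-yl in place of furan-3-yl on an aromatic carbon of a five-membered aromatic ring with 1 nitrogen: 1-benzofuran-2-yl in place of furan-3-yl on an aromatic carbon. Within the data shown here, only one measured step touches this position, thiophen-3-yl in place of furan-3-yl, and it amounts to an at least 1.4-fold higher number from compound 1 to compound 2 (0.14 log units; that floor lies within the scatter). That step was taken on the core of compound 1 and adds no six-membered aromatic ring, so it offers only a loose guide. No shift beyond the scatter can be firmly expected, and the expected change is a 1.1-fold lower number from compound 3 to compound 4 (0.05 log units; within the scatter) in this assay with wide uncertainty. Compound 4 may also report only a limit. For compound 4 the estimate is 16000 nM, with an expected range from 6000 nM to 40000 nM.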

Compound 4, half-maximal inhibitory concentration: > 20000 nM
Compound 4: only a limit was reported (the forecaster's own chance of this, stated with the estimate: 45%); middle value at least 1.2-fold (0.09 log units) away from the limit.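

On the core of compound 3, 1-benzofuran-2-yl in place of furan-3-yl adds a six-membered aromatic ring of carbon only, and in this assay this gives an at least 1.1-fold higher number from compound 3 to compound 4 (0.04 log units; that floor lies within the scatter). The value of compound 4 is a limit of the assay, so the step gives only a floor, but it shows that this larger group brought no stronger inhibition on a core other than that of compound 1. The read-out leaves little room to resolve changes at this position: the limit of > 20000 nM in this assay, at which 2 of the 4 values shown sit.

Still open, from the compounds shown here alone, is whether any group at this position can bring the number clearly down, since only furan-3-yl, thiophen-3-yl and 1-benzofuran-2-yl appear there. Going by these compounds, how an amine or a carboxylic acid in that place would read, or thiophen-3-yl on the core of compound 3, remains unknown.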